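Removing the Acetyl Group from Compound 1

This account rests on a few compounds, and the source may have more. Where it says the series, first, only, none or still open, it means among the compounds named here.

Measured compounds:
compound 1 `CCCCn1c(=O)n(Cc2ccccc2F)c(=O)c2[nH]c(Cc3ccc(NC(C)=O)cc3)nc21` — in an assay on isolated protein for inhibition of phosphoenolpyruvate carboxykinase, cytosolic [GTP] (Homo sapiens) (on this read-out higher numbers stand for weaker inhibition and lower numbers for stronger inhibition), compound 1 gives 2110 nM
compound 2 `Cc1nn(C)cc1S(=O)(=O)Nc1ccc(Cc2nc3c([nH]2)c(=O)n(Cc2ccccc2F)c(=O)n3CC2CC2)cc1` — compound 2 gives 240 nM
compound 3 `Cn1cc(S(=O)(=O)Nc2ccc(Cc3nc4c([nH]3)c(=O)n(Cc3ccccc3F)c(=O)n4CC3CC3)cc2)cn1` — compound 3 gives 390 nM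

Compound 1 stands at the highest number of the three, and its gap to each of compound 2 and compound 3 lies beyond the scatter. Compound 4 `CCCCn1c(=O)n(Cc2ccccc2F)c(=O)c2[nH]c(Cc3ccc(N)cc3)nc21` differs from compound 1 in one place: hydrogen in place of acetyl on a nitrogen on an aromatic ring. Within the data shown here, the only measured single-point step, a 1.6-fold higher number from compound 2 to compound 3 (0.21 log units; within the scatter), concerns a different position on different compounds, so no measured step bears on the change from acetyl to hydrogen. Compounds 2 and 3 differ from compound 1 in two places, so their values only show that other groups on that nitrogen give lower numbers. The step from compound 1 to compound 4 is therefore expected to be small, a 1.4-fold higher number from compound 1 to compound 4 (0.15 log units; within the scatter). Compound 4 is estimated at 3000 nM in this assay, within a range from 1000 nM to 9000 nM.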

Compound 4, half-maximal inhibitory concentration: 2560 nM
For compound 4 the middle estimate is 1.2-fold (0.07 log units) above the measured one; low and high end bracket the measured number.
By their numbers in this assay, from the lowest: compounds 2 and 3 (each within the scatter of the next); then compounds 1 and 4 (each within the scatter of the next).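

In this assay, hydrogen in place of acetyl on a nitrogen on an aromatic ring gives a 1.2-fold higher number from compound 1 to compound 4 (0.08 log units; within the scatter). This first measured step at this position shows that, on the core of compound 1, the number does not depend on the acetyl group, and acetamido and amino cannot be told apart here. No supporting measurement is available to explain this result.

Going by these compounds, it remains open whether a longer acyl chain, a methanesulfonyl group or a carboxylic acid on this nitrogen would move the number beyond the scatter.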